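Fluoro for Amino on Two Related Cores

This account rests on a few compounds, and the source may have more. Where it says the series, first, only, none or still open, it means among the compounds named here.

Compound 1 `CC(=O)OC(C)n1cnc2c(S)nc(N)nc21`: 10000 nM
Compound 2 `CC(=O)OCCOn1cnc2c(S)nc(N)nc21`: 4900 nM
Compound 3 `CC(=O)OC(C)n1cnc2c(S)nc(F)nc21`: 200000 nM

All three were measured in a functional assay on HEp-2 cells (Homo sapiens) for inhibition; a higher number here means a weaker inhibitor, a lower number a stronger inhibitor. Compound 2 gives the lowest number of the three; compound 1 lies higher by a step beyond the scatter, and compound 3 higher still. Compound 3 is compound 1 with fluoro in place of amino on an aromatic carbon, and this change gave a 20-fold higher number from compound 1 to compound 3 (1.30 log units; beyond the scatter). How the core of compound 1 differs from that of compound 2 is not broken down here.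

Compound 4 `CC(=O)OCCOn1cnc2c(S)nc(F)nc21` has not yet been measured. Among the measured compounds shown here, it is compound 2 with fluoro in place of amino on an aromatic carbon, the same change at the same place as the one from compound 1 to compound 3, the two place descriptions agreeing word for word. The step expected here, a 20-fold higher number from compound 2 to compound 4 (1.31 log units; beyond the scatter), is sized after a 20-fold higher number from compound 1 to compound 3 (1.30 log units; beyond the scatter) as the one measured case of this change. Compound 4 is therefore estimated at 100000 nM in this assay, with a range from 30000 nM to 300000 nM.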

Compound 4, half-maximal inhibitory concentration: > 500000 nM
Compound 4: no number, only a limit (the forecaster's own chance of this, stated with the estimate: 15%); middle value at least 5.0-fold (0.69 log units) away from the limit.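

In this assay, fluoro in place of amino on an aromatic carbon moved the number the same way on both cores, with an at least 100-fold higher number from compound 2 to compound 4 (2.00 log units; beyond the scatter), so the direction of the change carried from the core of compound 1 to the core of compound 2. The size did not carry over, since the two steps differ by more than the scatter: the same change on two cores in this assay, a 20-fold higher number (1.30 log units; beyond the scatter) from compound 1 to compound 3 and an at least 100-fold higher number (2.00 log units; beyond the scatter) from compound 2 to compound 4, at least 5.1-fold (0.70 log units) apart, beyond the scatter of two such steps. Compound 4 gave only a limit and not a number, so its step has a lower bound but no fixed size, and two cores cannot show a general rule for the series: the limit of > 500000 nM in this assay, at which 1 of the 4 values shown sits.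

The compounds shown leave open what in the two cores goes with the difference in step size, and how large the step on the core of compound 2 really is. They also leave open how a chloro group, a methylamino group or a plain hydrogen in place of amino at this position would read on either core, and whether any of these would carry from one core to the other.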